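Benzyl for Phenyl on the Imidazole Nitrogen

The compounds below may be only part of what the source reports. "The series", "measured", "known", "first", "only" and "open" are said of these compounds alone.

The measured compounds:
compound 1, `N#Cc1ncn(-c2ccc(F)cc2)c1/N=C/c1ccc([N+](=O)[O-])cc1`, 15900 nM
compound 2, `COc1cc(/C=N/c2c(C#N)ncn2-c2ccc(F)cc2)ccc1O`, 20100 nM
compound 3, `N#Cc1ncn(Cc2ccc(F)cc2)c1/N=C/c1ccc([N+](=O)[O-])cc1`, 5720 nM

All three were tested in a functional assay on HT-29 cells (Homo sapiens) for antiproliferative activity, read by MTT assay, with a stated time of 48 h; on this read-out higher numbers stand for weaker inhibition and lower numbers for stronger inhibition. Compound 2 gives the highest number of the three, and its value sits within the scatter of that of compound 1, so no order between the two is claimed. The difference between the cores of compound 1 and compound 2 is not broken down here. Compound 3 differs from compound 1 in one place, (4-fluorobenzyl in place of 4-fluorophenyl on an aromatic nitrogen), and that step gave a 2.8-fold lower number from compound 1 to compound 3 (0.44 log units; beyond the scatter).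

Compound 4, `COc1cc(/C=N/c2c(C#N)ncn2Cc2ccc(F)cc2)ccc1O`, is not yet measured. It differs from compound 2 by the same change, (4-fluorobenzyl in place of 4-fluorophenyl on an aromatic nitrogen), at the same place. Because compound 1 to compound 3 gave a 2.8-fold lower number from compound 1 to compound 3 (0.44 log units; beyond the scatter), a step of similar size is expected, a 2.7-fold lower number from compound 2 to compound 4 (0.43 log units; beyond the scatter), resting on that single precedent. Compound 4 is therefore estimated at 7500 nM, between 3500 nM and 18000 nM.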

Compound 4, half-maximal inhibitory concentration: 21500 nM
Estimate against measurement, compound 4: 2.9-fold (0.46 log units) below; the whole stated range lies below it.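

In this assay the placing of 4-fluorobenzyl in place of 4-fluorophenyl on the core of compound 2 gave a 1.1-fold higher number from compound 2 to compound 4 (0.03 log units; within the scatter) and so did not repeat the earlier step. The effect of this change therefore differs between the two cores: the same change on two cores in this assay, a 2.8-fold lower number (0.44 log units; beyond the scatter) from compound 1 to compound 3 and a 1.1-fold higher number (0.03 log units; within the scatter) from compound 2 to compound 4, 3.0-fold (0.47 log units) apart, beyond the scatter of two such steps. This shows that the step cannot be carried from the core of compound 1 to that of compound 2, but with one pair on each core it does not show which difference between the cores matters or how the change would behave on a third core.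

Still open, from the compounds shown here alone, is whether a longer chain, such as 2-phenylethyl, on the aromatic nitrogen would follow either step. Also open, going by these compounds, is how the change behaves on a core bearing an amine or a carboxylic acid.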